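A few compounds are considered here, and "the series" means these few. Any claim that something is new, unique, unknown or untested is made for them only; others in the source may bear on it.

Three related compounds have been tested so far in a functional assay on L1210 cells (Mus musculus) for inhibition; a higher number here means a weaker inhibitor, a lower number a stronger inhibitor. In this test, compound 1 `C=C1[C@@H](O)[C@H](n2ccc(N)nc2=O)O[C@@H]1CO` gives 378000 nM. Compound 2 `C=C1C(n2ccc(N)nc2=O)O[C@H](CO)[C@@H]1O` gives 2000 nM, a lower number, which makes it the stronger inhibitor of the two. For compound 3 `C=C1[C@@H](O)[C@H](n2cnc3c(N(C)C)nc(N)nc32)O[C@@H]1CO` the result is only a limit of the assay, > 500000 nM, and not a number.

Compound 4 `C=C1[C@@H](O)[C@H](n2cnc3c(SC)nc(N)nc32)O[C@@H]1CO` differs from compound 3 in one place: it has methylsulfanyl in place of dimethylamino on an aromatic carbon. Among the measured compounds shown here, no measured pair shows what this swap does, so the forecast is loose. It rests on two facts. Compound 3 gave no number, and compound 4 keeps the part of the molecule that compound 3 shares with compound 1, which gives 378000 nM in this assay. Inhibition is therefore expected to stay very weak, with at most a modest shift towards a stronger result, and compound 4 may well return only a limit too. The expected step is an at least 1.6-fold lower number from compound 3 to compound 4 (0.22 log units; that floor lies within the scatter). For compound 4 the estimated value is 300000 nM, with an expected range of 60000 nM to 500000 nM.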

Compound 4, half-maximal inhibitory concentration: > 500000 nM
Compound 4 was reported as a limit; the forecaster's own chance of this, stated with the estimate: 50%; middle value at least 1.6-fold (0.22 log units) away from the limit.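

No step can be read from compound 3 to compound 4, because neither gave a number and both results stop at the same end of the test: the limit of > 500000 nM in this assay, at which 2 of the 4 values shown sit.

The compounds shown leave open whether methylsulfanyl or dimethylamino on this aromatic carbon gives the stronger inhibitor in this assay, and by how much.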